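The source may report more compounds than this note shows. Statements on the series, on what has been measured and on what is new or still open speak of the compounds shown alone.

Compound 3, `CCCCOC(=O)CNC(=O)[C@H](CSc1ccc([N+](=O)[O-])cc1[N+](=O)[O-])NC(=O)CC[C@H](NC(=O)C(C)(C)C)C(=O)OCCCC`, is tested in a toxicity assay on KB cells (Homo sapiens) for cytotoxicity, read by fluorescence, with a stated time of 3 days (on this read-out higher numbers stand for an effect only at larger amounts of compound and lower numbers for an effect already at smaller amounts), where compound 3 gives 83.4 uM. Among the three compounds measured so far, compound 3 is the only one with a number; the other two values are limits of the assay. Compound 1, `CCCCCCCCCCCCCC(=O)N[C@@H](CCC(=O)N[C@@H](CSc1ccc([N+](=O)[O-])cc1[N+](=O)[O-])C(=O)NCC(=O)OCCCC)C(=O)OCCCC`, reaches only a limit of the assay in this assay, > 300 uM. Compound 2, `CCCCOC(=O)CNC(=O)[C@H](CSc1ccc([N+](=O)[O-])cc1[N+](=O)[O-])NC(=O)CC[C@H](NC(=O)CCc1ccccc1)C(=O)OCCCC`, likewise reaches only a limit of the assay in this assay, > 300 uM. The step that the two limits leave unreadable from compound 1 to compound 2 is therefore not readable, while the step of an at least 3.5-fold lower number from compound 2 to compound 3 (0.55 log units; beyond the scatter) is read from a limit and is at least modest, with the limit of > 300 uM in this assay, at which 2 of the 3 values shown sit, setting the edge of what is seen.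

Compound 4, `CCCCOC(=O)CNC(=O)[C@H](CSc1ccc([N+](=O)[O-])cc1[N+](=O)[O-])NC(=O)CC[C@H](NC(=O)CCC(C)C)C(=O)OCCCC`, differs from compound 3 in one place: isopentyl in place of tert-butyl on a carbonyl carbon. This change also bears on the acyl group on the nitrogen, the same position changed in the step from compound 2 to compound 3. On that basis a somewhat higher number is expected for compound 4, a 1.8-fold higher number from compound 3 to compound 4 (0.25 log units; within the scatter), and compound 4 is estimated at 150 uM, within a range from 60 uM to 300 uM.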

Compound 4, concentration for half-maximal effect: 84 uM
For compound 4 the middle estimate is 1.8-fold (0.25 log units) above the measured one; low and high end bracket the measured number.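

At this acyl group on the amide-type nitrogen, this assay does not tell tert-butyl and isopentyl apart: the exchange gives a 1.0-fold higher number from compound 3 to compound 4 (0.00 log units; within the scatter). With compound 4, a second small acyl group now reads apart from the larger ones, as isopropyl in place of phenyl on the saturated chain carbon gives an at least 3.5-fold lower number from compound 2 to compound 4 (0.55 log units; beyond the scatter), and isopropyl in place of undecyl gives an at least 3.5-fold lower number from compound 1 to compound 4 (0.55 log units; beyond the scatter). Both of these steps start from a limit of the assay, so they fix only the least size of the difference, and the edge of what is seen remains: the limit of > 300 uM in this assay, at which 2 of the 4 values shown sit.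

The compounds shown leave open where, on a longer chain between isopentyl and undecyl, the number reaches that limit. They also leave open how an acyl group carrying an amine or a carboxylic acid would read in this assay.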